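Swapping a Nitrile for a Larger Group

The source may report more compounds than this note shows. Statements on the series, on what has been measured and on what is new or still open speak of the compounds shown alone.

Of the compounds shown here, three have been measured so far in a physicochemical assay for solubility, read by nephelometry, measured as kinetic solubility, at pH 2, tested at 10 mg/mL (a lower number here means a less soluble compound, a higher number a more soluble compound), and they do not all sit together. Compound 1 `Cc1ccccc1C(=O)Nc1ncccn1` gives 6.3 ug/mL and compound 2 `Cc1c(F)cccc1C(=O)Nc1ccccn1` gives 50 ug/mL in this test. Compound 3 `Cc1ccccc1C(=O)Nc1cc(C#N)ccn1` gives 50 ug/mL here, level with compound 2 and clearly above compound 1.

Compound 4 `Cc1ccccc1C(=O)Nc1cc(C#Cc2ccccc2)ccn1` carries 2-phenylethynyl in place of the cyano of compound 3 on an aromatic carbon (2-phenylethynyl in place of cyano on an aromatic carbon). For the measured compounds named here, no two measured compounds differ in one place only, so no measured step guides this swap. A lower number in this assay is still expected, by a margin beyond the scatter. The estimated step of a 4.2-fold lower number from compound 3 to compound 4 (0.62 log units; beyond the scatter) is only a judgement. Compound 4 is expected near 12 ug/mL with an estimated range from 3 ug/mL to 40 ug/mL around that figure.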

Compound 4, solubility: 1.6 ug/mL
Compound 4: middle estimate off by 7.5-fold (0.88 log units), on the high side; the measured number lies below the stated range.
By their numbers in this assay, from the lowest: compound 4; then compound 1; then compounds 2 and 3 (each within the scatter of the next).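

In this assay, for the compounds shown here, the swap of cyano for 2-phenylethynyl on this aromatic carbon, opposite the ring nitrogen, brings a 31-fold lower number from compound 3 to compound 4 (1.49 log units; beyond the scatter) and gives the first change in one place that can be read. The number at this position therefore depends strongly on the group it carries, and here the larger group, with its added aromatic ring, goes with the lower number. Nothing measured here gives the reason for this drop.

As far as these compounds go, whether an amine or a carboxylic acid on this carbon would raise or lower the number stays open. So does whether the same swap would act alike on the core of compound 1 or compound 2.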